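Clearance Limits Across Three Acids and a Primary Amide

The source may hold more compounds than are shown below. What is called first, only, known or untested is meant among the compounds shown, and "the series" means these compounds.

compound 1, `CC(C)(C(=O)O)N1CCCN(c2ccc(F)c(C(F)(F)F)c2)C1=O`: in an ADME assay on microsomes from liver (Mus musculus) for metabolic stability, using NADPH, with a stated time of 60 min (a lower number here means slower removal, a higher number faster removal of the compound), compound 1 gives < 7 uL/min, which is a limit of the assay.
compound 2, `CC(C)(CC(=O)Nc1ccc(F)c(C(F)(F)F)c1)C(=O)O`: in this assay compound 2 gives < 7 uL/min, also a limit of the assay.
compound 3, `O=C(O)CNC(=O)Nc1ccc(F)c(C(F)(F)F)c1`: in this assay compound 3 gives < 7 uL/min, again a limit of the assay.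

Compound 3 thus stands where every measured compound stands, at the limit of < 7 uL/min in this assay, at which 3 of the 3 values shown sit, so nothing beneath that limit can be read for it. Among the measured compounds shown here, the only step between measured compounds, a step that the two limits leave unreadable from compound 2 to compound 3, has no readable size, and no other step is available. The next compound, compound 4, `CC(C)(NC(=O)Nc1ccc(F)c(C(F)(F)F)c1)C(N)=O`, differs from compound 3 by 1-carbamoyl-1-methylethyl in place of carboxymethyl on an amide-type nitrogen. For the measured compounds named here, since every value so far has come back as the same limit and no step carries a size, the account can only say that the change from compound 3 to compound 4 is expected to give a step that the limit leaves unreadable from compound 3 to compound 4, not a step beyond the scatter. Compound 4 is therefore expected to show about 5 uL/min in this assay, with a range from 2 uL/min to 15 uL/min, most likely reported again as a limit rather than a number.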

Compound 4, intrinsic clearance in a liver preparation (reported as CLH), per the amount of preparation that the assay uses: 18 uL/min
For compound 4 the middle estimate is 3.6-fold (0.56 log units) below the measured one, outside the stated range (above it).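

Placing 1-carbamoyl-1-methylethyl in place of carboxymethyl on an amide-type nitrogen gives, in this assay, an at least 2.5-fold higher number from compound 3 to compound 4 (0.41 log units; beyond the scatter), the first step in the series with a readable size, which shows that a change at this position can lift the read-out off the limit. The change of 2-carboxy-2-methylpropyl on a carbonyl carbon to (1-carbamoyl-1-methylethyl)amino gives an at least 2.5-fold higher number from compound 2 to compound 4 (0.41 log units; beyond the scatter). Both sizes are only lower bounds, because the starting compound of each step sits at a limit: the limit of < 7 uL/min in this assay, at which 3 of the 4 values shown sit.

The compounds shown leave open whether the step follows the carbamoyl group or the 1-methylethyl part of the new chain, since both enter together. A carbamoylmethyl group or a 1-carboxy-1-methylethyl group on that nitrogen would separate the two.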